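This account rests on a few compounds, and the source may have more. Where it says the series, first, only, none or still open, it means among the compounds named here.

Measured compounds:
- Compound 1, `COc1cccc(/C=C2\CCCc3ccccc3C2=O)c1OC`: 142000 nM
- Compound 2, `O=C1/C(=C/c2ccc(Cl)cc2Cl)CCCc2ccccc21`: 407000 nM
- Compound 3, `O=C1/C(=C/c2ccccc2Br)CCCc2ccccc21`: 32100 nM

In a functional assay on CCRF-CEM cells (Homo sapiens) for inhibition (on this read-out higher numbers stand for weaker inhibition and lower numbers for stronger inhibition), compound 3 gives 32100 nM, the lowest number of the three. Compound 1, with 142000 nM, and compound 2, with 407000 nM, both stand higher than compound 3 by margins beyond the usual scatter, so compound 3 is the strongest inhibitor among the measured compounds. Among the measured compounds shown here, these three compounds differ in more than one place, so no single structural step between any pair of them can be read off.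

Compound 4, `O=C1/C(=C/c2ccccc2Cl)CCCc2ccccc21`, is not yet measured. It differs from compound 3 in one place: chloro in place of bromo on an aromatic carbon. For the measured compounds named here, no step of this kind is available among the measured compounds, so the expectation rests on the change itself, which is a small one. No step beyond the scatter is expected in either direction in this assay. Compound 4 is therefore expected to give about 40000 nM, with a likely range from 15000 nM to 110000 nM. That corresponds to an expected step of a 1.2-fold higher number from compound 3 to compound 4 (0.10 log units; within the scatter), which would lie within the scatter.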

Compound 4, half-maximal inhibitory concentration in the CCRF-CEM assay: 18400 nM
Beside the measured number, compound 4's estimate is 2.2-fold (0.34 log units) above it; low and high end bracket the measured number.
By their numbers in the CCRF-CEM assay, from the lowest: compounds 4 and 3 (each within the scatter of the next); then compound 1; then compound 2.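

In the CCRF-CEM assay, compound 3 gives 32100 nM and compound 4 gives 18400 nM; chloro in place of bromo on an aromatic carbon ortho to a large group gives a 1.7-fold lower number from compound 3 to compound 4 (0.24 log units; within the scatter), so this read-out does not separate the two halogens at this position. In a physicochemical assay for lipophilicity (on this read-out lower numbers stand for lower lipophilicity and higher numbers for higher lipophilicity), compound 3 gives 5.04 and compound 4 gives 5.04; the same exchange gives no change at the digits printed from compound 3 to compound 4 (within the scatter), so lipophilicity does not separate them either. Back in the CCRF-CEM assay, hydrogen in place of chloro on an aromatic carbon gives a 22-fold lower number from compound 2 to compound 4 (1.34 log units; beyond the scatter), the first single change shown to move inhibition beyond the scatter, with the extra chloro on the side of weaker inhibition.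

Nothing at hand explains either step. Going by these compounds, whether an amine or a carboxylic acid on the same aromatic carbon would keep, strengthen or lose the inhibition remains open.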